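This account rests on a few compounds, and the source may have more. Where it says the series, first, only, none or still open, it means among the compounds named here.

Working notes on the series.

Two compounds of the shared core carry numbers in a functional assay on HOP-92 cells (Homo sapiens) for cytotoxicity, read by sulforhodamine B assay, with a stated time of 48 h, tested at 0.01 uM; on this read-out lower numbers stand for a stronger effect and higher numbers for a weaker effect at the one concentration tested. Compound 1 `COc1cc(C)cc(-c2nn(CC#N)cc2-c2ccc(-c3cccc(C(C)=O)c3)nc2)c1` gives 80% in this assay. Compound 2 `Cc1cc(O)cc(-c2nn(CC#N)cc2-c2ccnc(-c3ccc(Oc4ccccc4)cc3)c2)c1` gives 59% in this assay. Of the two numbers, compound 2 stands lower, and its gap to compound 1 lies beyond the scatter of this assay, so the two are told apart. Among the compounds with values here, no single-point step between measured compounds is at hand, so nothing in the measured data speaks to what one change at one place does here.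

Compound 3 `Cc1cc(O)cc(-c2nn(CC#N)cc2-c2ccnc(-c3ccc(N(C)C)cc3)c2)c1` has not yet been measured in this assay. It differs from compound 2 in one place: dimethylamino in place of phenoxy on an aromatic carbon. The phenoxy group leaves and the dimethylamino group enters on an aromatic carbon of a six-membered aromatic ring of carbon only, para to a large group. Within the data shown here, with no measured step to rest on, the expected step from compound 2 to compound 3 in this assay is a number 5 percentage points higher from compound 2 to compound 3 (within the scatter), that is, none beyond the scatter, with the direction left open. The estimate for compound 3 in this assay is therefore 64%, within a range from 44% to 84%.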

Compound 3, a percentage reported as activity, at one concentration (the size of the read-out at that concentration, not a potency): 85%
Compound 3: the middle estimate sits 21 percentage points below what was measured, outside the stated range (above it).
By their numbers in this assay, from the lowest: compound 2; then compounds 1 and 3 (each within the scatter of the next).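

In this assay, dimethylamino in place of phenoxy on an aromatic carbon, para to a large group, gives a number 26 percentage points higher from compound 2 to compound 3 (beyond the scatter) and is the first single-place step in the series, so the group at this position is shown to matter in this read-out. The change takes away a six-membered aromatic ring of carbon only and goes from 7 heavy atoms to 3, while each group has 0 hydrogen-bond donors and 1 hydrogen-bond acceptor, so the two groups do not differ in these counts of donors and acceptors. No measurement at hand explains the step.

The compounds shown hold only these two groups at this carbon, so this one pair cannot separate the part played by the aromatic ring of phenoxy from that of its oxygen or of the number of heavy atoms. Going by these compounds, a benzyloxy group, a methoxy group, a morpholine or a carboxylic acid on the same carbon would bear on that question, and the size of the step at other concentrations also stays open.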